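A Chloro Step in a Low-Inhibition Series

The source may report more compounds than this note shows. Statements on the series, on what has been measured and on what is new or still open speak of the compounds shown alone.

Measured in a functional assay on HO8910 cells (Homo sapiens) for inhibition, read by MTT assay, with a stated time of 24 h, tested at 0.1 ug/mL; on this read-out higher numbers stand for more inhibition of growth at the one concentration tested and lower numbers for less inhibition of growth:
Compound 1 `O=C(CCCCC1CCSS1)Nc1ccccn1` gives 1.14%
Compound 2 `O=C(CCCCC(S)CCS)Nc1ccc([N+](=O)[O-])c(C(F)(F)F)c1` gives 1.95%
Compound 3 `O=C(CCCCC(CCSC(=O)c1ccccc1)SC(=O)c1ccccc1)Nc1ccccc1` gives 3.12%

Compound 3 stands at 3.12% in this assay, within the usual scatter of both compound 1 and compound 2, so the three values cannot be ranked. Among the compounds with values here, these compounds differ from one another in more than one place, and no measured pair differs in one place only. The data therefore hold no direct measure of the change that comes next.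

Compound 4 `O=C(CCCCC(CCSC(=O)c1ccccc1)SC(=O)c1ccccc1)Nc1cccc(Cl)c1` is not yet measured. It departs from compound 3 by a single change: chloro in place of hydrogen on an aromatic carbon. Thus the phenyl of compound 3 becomes the 3-chlorophenyl of compound 4, with the chloro meta to a large group.

The measured structures differ in several places, yet compound 1 at 1.14% and compound 2 at 1.95% remain within the scatter of compound 3. On that basis, no step beyond the scatter is expected in this assay, and no firm direction can be assigned. The estimated change is a number 0.9 percentage points higher from compound 3 to compound 4 (within the scatter), which is expected to stay within the scatter. For compound 4 the expected value is 4%, with an estimated range from 0% to 12%.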

Compound 4, percent growth inhibition at one concentration: 9.02%
Estimate against measurement, compound 4: 5 percentage points below; the measured number falls inside the stated range.
By their numbers in this assay, from the lowest: compounds 1, 2, 3 and 4 (each within the scatter of the next).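

The chloro step gives this series its first comparison between compounds that differ in one place, and in this assay it reads a number 5.9 percentage points higher from compound 3 to compound 4 (within the scatter) for chloro in place of hydrogen on an aromatic carbon, meta to a large group. Within the data shown here, at the one concentration tested, this read-out therefore cannot tell the 3-chlorophenyl of compound 4 from the phenyl of compound 3, a direct finding on this position that the earlier compounds, with their several differences, could not give. Nothing measured here bears on the reason for this result.

On these data alone, it remains open whether another group at this place, such as a methoxy, a nitrile or an amine, or a chloro elsewhere on the same aromatic ring, would give a step beyond the scatter. Also open, as far as these compounds go, is whether the change from phenyl to 3-chlorophenyl would read the same way on a different remainder of the molecule, such as the free thiols of compound 2, or at a higher concentration in this assay.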